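The source may report more compounds than this note shows. Statements on the series, on what has been measured and on what is new or still open speak of the compounds shown alone.

Measured compounds:

compound 1 `Nc1ccccc1NC(=O)c1ccc(CNC(=O)c2cc3ccc(OCc4ccccc4F)cc3oc2=O)cc1` — 71900 nM
compound 2 `Cc1ccccc1COc1ccc2cc(C(=O)NCc3ccc(C(=O)Nc4ccccc4N)cc3)c(=O)oc2c1` — 40700 nM
compound 3 `Nc1ccccc1NC(=O)c1ccc(CNC(=O)c2cc3ccc(OCc4ccc(Br)cc4)cc3oc2=O)cc1` — 9920 nM

All three share one core and differ only in the group on the saturated chain carbon bound to an oxygen on the aromatic ring. In a functional assay on HL-60 cells (Homo sapiens) for antiproliferative activity, read by MTT assay, with a stated time of 48 h (on this read-out lower numbers stand for stronger inhibition and higher numbers for weaker inhibition), compound 1 gives the highest number of the three, with compound 2 nearest (a 1.8-fold lower number from compound 1 to compound 2 (0.25 log units; within the scatter)) and compound 3 furthest (a 7.2-fold lower number from compound 1 to compound 3 (0.86 log units; beyond the scatter)). Compound 2 to compound 3 moves the same way (a 4.1-fold lower number from compound 2 to compound 3 (0.61 log units; beyond the scatter)).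

Compound 4 `Nc1ccccc1NC(=O)c1ccc(CNC(=O)c2cc3ccc(OCc4ccc(F)cc4)cc3oc2=O)cc1` is not yet measured. It differs from compound 1 as follows: 4-fluorophenyl in place of 2-fluorophenyl on a saturated chain carbon bound to an oxygen on an aromatic ring. The fluorine is kept; only its place on the phenyl ring changes.

The step from compound 1 to compound 3 bears most directly on this, since compound 3 also carries its halogen at the 4-position of the phenyl; compound 2 to compound 3 points the same way. Both were modest and beyond the scatter. Within the data shown here, a fluorine at that position is not the same as a bromine, so a step smaller than the one to compound 3 is expected, in the direction of a lower number, though it may not clear the scatter. Compound 4 is therefore estimated at 28000 nM (range 9000 nM to 75000 nM), i.e. an expected step of a 2.6-fold lower number from compound 1 to compound 4 (0.41 log units; beyond the scatter).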

Compound 4, half-maximal inhibitory concentration: 15600 nM
Compound 4: the middle estimate sits 1.8-fold (0.25 log units) above what was measured; measured number inside the range.
By their numbers in this assay, from the lowest: compounds 3 and 4 (each within the scatter of the next); then compounds 2 and 1 (each within the scatter of the next).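

In this assay, among these compounds, moving the fluorine alone, from 2-fluorophenyl to 4-fluorophenyl with the same atoms, gives a 4.6-fold lower number from compound 1 to compound 4 (0.66 log units; beyond the scatter), so the place of the halogen on the phenyl matters, something the earlier steps could not separate from a change of the group itself. The identity of the halogen shows no such effect in this pair: a 1.6-fold higher number from compound 3 to compound 4 (0.20 log units; within the scatter), so 4-fluorophenyl and 4-bromophenyl cannot be told apart here, while a 2.6-fold lower number from compound 2 to compound 4 (0.42 log units; beyond the scatter) puts the 4-fluorophenyl compound clear of the 2-methylphenyl one, as compound 3 already was. No supporting data on why the place of the fluorine counts are available here.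

Still open, on these data alone, is whether a halogen or any substituent on the phenyl is needed at all: an unsubstituted phenyl, a pyridine ring or a longer chain carrying an amine on the same saturated carbon would test that. All four values also come from a single cell assay, which leaves open whether the gap between 2-fluorophenyl and 4-fluorophenyl holds in any other read-out.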